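Working notes: methyl removal in a small amide series

The source may report more compounds than this note shows. Statements on the series, on what has been measured and on what is new or still open speak of the compounds shown alone.

Measured so far:
compound 1 `Cc1cccc(N(C)C(=O)c2ccc(Oc3ccccc3C)cc2)c1` – "not active" (no number reported)
compound 2 `COc1cccc(N(C)C(=O)C2CCC(c3ccc(Cl)cc3)CC2)c1` – 60100 nM

In an assay for inhibition of 17-beta-hydroxysteroid dehydrogenase type 1 (Homo sapiens), read by HPLC, with a stated time of 10 min (a lower number here means a stronger inhibitor, a higher number a weaker inhibitor), compound 1 gives "not active" (no number reported), so no number places it on a scale. In this assay compound 2 gives 60100 nM, a weak result. Compound 3 `Cc1cccc(N(C)C(=O)c2ccc(Oc3ccccc3)cc2)c1` differs from compound 1 by hydrogen in place of methyl on an aromatic carbon. For the measured compounds named here, no step between measured compounds exists to size this change; with compound 1 inactive and compound 2 weak, no gain beyond the scatter is expected. Compound 3 is estimated at 80000 nM, range 20000 nM to 300000 nM.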

Compound 3, half-maximal inhibitory concentration: "not active" (no number reported)
For compound 3 the study gives words and no number, and the estimate cannot be compared.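

Compound 1 and compound 3 both lack a number in this assay, and no step can be read between them. As far as these compounds go, whether the change from 2-methylphenoxy to phenoxy alters inhibition stays open. No further data bear on this result.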